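Ethyl to Methoxy on an Acid Already at the Limit

The compounds below may be only part of what the source reports. "The series", "measured", "known", "first", "only" and "open" are said of these compounds alone.

Measured so far:
compound 1, `CCc1cccc2c(OC)c(-c3occ(C)c3C(=O)OC)ccc12`: 2.3 ug/mL
compound 2, `CCc1cccc2c(O)c(-c3occ(C)c3C(=O)O)ccc12`: > 10 ug/mL

Compound 1 was tested in a functional assay on MDA-MB-231 cells (Homo sapiens) for cytotoxicity, read by sulforhodamine B assay, with a stated time of 72 h (a higher number here means that more compound is needed for the effect, a lower number that less compound is needed), and gives 2.3 ug/mL. Compound 2 reaches in this assay only a limit, > 10 ug/mL, so for compound 2 a number is not known, only that it lies past the limit, as the limit of > 10 ug/mL in this assay, at which 1 of the 2 values shown sits, records. Going by the values given here, the two structures differ in more than one place, so the comparison says only that compound 1 gives a number while compound 2 does not.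

Compound 3, `COc1cccc2c(O)c(-c3occ(C)c3C(=O)O)ccc12`, has not yet been measured. It differs from compound 2 by methoxy in place of ethyl on an aromatic carbon, on an aromatic carbon of a six-membered ring of carbon only, part of a fused system of two rings. Both groups are small and uncharged, and compound 2 already sits at the limit, so the expected step that the limit leaves unreadable from compound 2 to compound 3 is none beyond the usual scatter. Compound 3 is expected to give about 15 ug/mL, most likely again only a limit, with a range from 5 ug/mL to 40 ug/mL.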

Compound 3, concentration for half-maximal effect: > 10 ug/mL
Compound 3: a limit, no number (the forecaster's own chance of this, stated with the estimate: 75%); the middle value does not contradict the limit.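

Compound 2 and compound 3 both stop at a limit rather than giving a number, so no step between them can be read: the limit of > 10 ug/mL in this assay, at which 2 of the 3 values shown sit.

Still open, from the compounds shown here alone, is how far past that limit each compound lies, and whether methoxy in place of ethyl changes anything in this assay.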